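A few compounds are considered here, and "the series" means these few. Any claim that something is new, unique, unknown or untested is made for them only; others in the source may bear on it.

Going by the values given here, compound 2 `CS(=O)(=O)Nc1ccc2c(c1)S(=O)(=O)N=C(C1=C(O)[C@H]3CCC[C@H]3N(Cc3ccc(C(F)(F)F)cc3)C1=O)N2` is one of two compounds measured in an ADME assay on Huh-7 cells (Homo sapiens) for cytotoxicity, with a stated time of 72 h; a lower number here means that less compound is tolerated, a higher number that more compound is tolerated. In this assay compound 2 reaches only a limit, reported as > 33000 nM. Compound 1 `CC(C)CCN1C(=O)C(C2=NS(=O)(=O)c3cc(NS(C)(=O)=O)ccc3N2)=C(O)[C@H]2CCC[C@H]21` likewise gives only a limit, reported as > 1000 nM. The step that the two limits leave unreadable from compound 1 to compound 2 is therefore unreadable. Compound 3 `Cc1cc(CN2C(=O)C(C3=NS(=O)(=O)c4cc(NS(C)(=O)=O)ccc4N3)=C(O)[C@H]3CCC[C@H]32)ccc1F` differs from compound 2 by 4-fluoro-3-methylphenyl in place of 4-(trifluoromethyl)phenyl on a saturated chain carbon bound to an amide-type nitrogen in a ring. Among the compounds with values here, no measured step bears directly on this change, and the two values shown are both limits, the limit of > 1000 nM in this assay, at which 1 of the 2 values shown sits, and (the limit of > 33000 nM in this assay, at which 1 of the 2 values shown sits). Compound 3 is expected to be tolerated at a similarly high concentration, with the step of a number no higher from compound 2 to compound 3 (the limit leaves the size open). Compound 3 is estimated at 33000 nM, between 8000 nM and 100000 nM.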

Compound 3, half-maximal cytotoxic concentration: > 1000 nM
Compound 3: a limit, no number; the forecaster's own chance of this, stated with the estimate: 70%; the middle value does not contradict the limit.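

In this assay compound 3 gives > 1000 nM, a limit and not a number. Going by these compounds alone, no step among compound 1, compound 2 and compound 3 can be read, as all three values are limits. The compounds shown leave open the actual tolerated concentration of each, and whether these changes of group alter it at all.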